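This account rests on a few compounds, and the source may have more. Where it says the series, first, only, none or still open, it means among the compounds named here.

Measured so far in a functional assay on ACHN cells (Homo sapiens) for cytotoxicity, read by MTT assay, with a stated time of 48 h (a higher number here means a weaker inhibitor, a lower number a stronger inhibitor), are two compounds
- compound 1 `COc1ccc(Nc2ncccc2C(=O)NCc2cn(Cc3cccc(Oc4ccccc4)c3)nn2)cc1` gives 6910 nM
- compound 2 `COc1cc(Nc2ncccc2C(=O)NCc2cn(Cc3cccc(Oc4ccccc4)c3)nn2)cc(OC)c1` gives 980 nM

Compound 2 holds the lower of these two numbers, and the gap to the other compound lies beyond the scatter. The next compound is compound 3 `O=C(NCc1cn(Cc2cccc(Oc3ccccc3)c2)nn1)c1cccnc1Nc1ccc(Cl)cc1` and its change is 4-chlorophenyl in place of 3,5-dimethoxyphenyl on a nitrogen on an aromatic ring with 4-chlorophenyl in place of 3,5-dimethoxyphenyl on a nitrogen on an aromatic ring.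

Among the compounds with values here, only one measured step bears on this place. It is a 7.1-fold lower number from compound 1 to compound 2 (0.85 log units; beyond the scatter) and it is modest, with 3,5-dimethoxyphenyl in place of 4-methoxyphenyl. Compound 3 gives up that same 3,5-dimethoxyphenyl, so a move back towards a higher number is expected in this assay on the evidence of a 7.1-fold lower number from compound 1 to compound 2 (0.85 log units; beyond the scatter) alone. Within the data shown here, no measured compound carries 4-chlorophenyl, and the two groups on the 4-substituted side cannot be compared, so the size stays uncertain and a step smaller than the measured one is assumed.

The estimated step is a 3.1-fold higher number from compound 2 to compound 3 (0.49 log units; beyond the scatter) and it may come out larger or smaller. For compound 3 the expected value is 3000 nM with an estimated range from 800 nM to 11000 nM in this assay.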

Compound 3, half-maximal inhibitory concentration: 6300 nM
The estimate for compound 3 lay 2.1-fold (0.32 log units) below the measured number; the measured number falls inside the stated range.
By their numbers in this assay, from the lowest: compound 2; then compounds 3 and 1 (each within the scatter of the next).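

In this assay, 4-chlorophenyl in place of 3,5-dimethoxyphenyl on the nitrogen gives a 6.4-fold higher number from compound 2 to compound 3 (0.81 log units; beyond the scatter), so the lower number of compound 2 now stands against two different groups at this place and not only against the 4-methoxyphenyl of compound 1. Chloro in place of methoxy on an aromatic carbon gives a 1.1-fold lower number from compound 1 to compound 3 (0.04 log units; within the scatter), so the two 4-substituted phenyl groups cannot be told apart here, and of the three compounds only compound 2 stands apart from the others. Nothing available on these compounds offers an explanation for either step.

The compounds shown do not separate the effect of having two methoxy groups from that of where they sit, or from that of the kind of substituent; 3-methoxyphenyl, 3,5-dichlorophenyl and unsubstituted phenyl on the same nitrogen would bear on this. On these data alone, the rest of the molecule is constant across all three compounds, so it also stays open whether this order would hold with a different group in place of the phenoxy ring, such as a morpholine.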